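This account rests on a few compounds, and the source may have more. Where it says the series, first, only, none or still open, it means among the compounds named here.

Compound 2 `C[C@]1(CN2CCc3nc(-c4ccc(C(F)(F)F)cc4)ccc3C2)Cn2cc([N+](=O)[O-])nc2O1` was tested in an ADME assay on Vero cells (Chlorocebus sabaeus) for cytotoxicity, read by MTT assay, with a stated time of 72 h; on this read-out higher numbers stand for lower toxicity in this test and lower numbers for higher toxicity in this test. In this assay compound 2 gives > 32 ug/mL, which is a limit of the assay rather than a number. Compound 1 `C[C@]1(CN2CCc3oc(-c4ccc(F)cc4)nc3C2)Cn2cc([N+](=O)[O-])nc2O1` gives > 32 ug/mL in this assay, again a limit. All the numbers show is the limit of > 32 ug/mL in this assay, at which 2 of the 2 values shown sit. Compound 3 `C[C@]1(CN2CCc3nc(-c4cccc(Cl)c4F)ccc3C2)Cn2cc([N+](=O)[O-])nc2O1` has not yet been measured. It differs from compound 2 by 3-chloro-2-fluorophenyl in place of 4-(trifluoromethyl)phenyl on an aromatic carbon. Among the compounds with values here, no measured step between two compounds exists here, so there is no pattern to lean on. The step that the limit leaves unreadable from compound 2 to compound 3 is expected to be none beyond the scatter. Compound 3 is therefore estimated at 40 ug/mL, between 20 ug/mL and 80 ug/mL, most likely reported again only as a limit.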

Compound 3, half-maximal cytotoxic concentration: > 32 ug/mL
Compound 3 gave a limit, no number; the forecaster's own chance of this, stated with the estimate: 80%; the middle value is on the limit's open side.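

Within the data shown here, compound 2 and compound 3 both give only a limit of the assay, so no step between them can be read in this assay. The compounds shown leave open whether 3-chloro-2-fluorophenyl in place of 4-(trifluoromethyl)phenyl changes toxicity at all.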